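Compound 3 to compound 4: ethyl to propargyl

The compounds below may be only part of what the source reports. "The series", "measured", "known", "first", "only" and "open" are said of these compounds alone.

- Compound 1 `CCn1c(-c2ccc(C)cc2C)cs/c1=N\C(=O)c1ccccc1`: 1950 nM
- Compound 2 `CCCCn1c(-c2ccc(C)cc2C)cs/c1=N\C(=O)c1ccccc1`: 196 nM
- Compound 3 `CCn1c(-c2ccccc2)cs/c1=N\C(=O)c1ccccc1`: 51.5 nM

All three values come from a functional assay on MDA-MB-231 cells (Homo sapiens), read by microscopy and transwell migration, with a stated time of 24 h; on this read-out higher numbers stand for weaker inhibition and lower numbers for stronger inhibition. Compound 3 gives the lowest number of the three, and its gaps to compound 2 and to compound 1 are both beyond the scatter.

The next compound, not yet measured, is compound 4 `C#CCn1c(-c2ccccc2)cs/c1=N\C(=O)c1ccccc1`. The change is ethynyl in place of methyl on a saturated chain carbon bound to an aromatic nitrogen.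

The closest evidence is a 9.9-fold lower number from compound 1 to compound 2 (1.00 log units; beyond the scatter). That modest step also extends the chain on the aromatic nitrogen, but with 2,4-dimethylphenyl on the core rather than the phenyl of compound 3. The large step of a 38-fold lower number from compound 1 to compound 3 (1.58 log units; beyond the scatter) lies at the other site and leaves the chain untouched. Within the data shown here, it bears only as a caution, since no measured pair tests a chain change with phenyl in place, and no measured compound carries a triple bond. A small move towards a lower number in this assay is therefore expected, smaller than the chain step and with a wide margin.

The expected step is a 1.7-fold lower number from compound 3 to compound 4 (0.23 log units; within the scatter). The estimate for compound 4 is 30 nM, with an expected range of 8 nM to 120 nM.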

Compound 4, half-maximal inhibitory concentration: 2780 nM
Compound 4: middle estimate off by 93-fold (1.97 log units), on the low side, and the stated range ends below it.
By their numbers in this assay, from the lowest: compound 3; then compound 2; then compounds 1 and 4 (each within the scatter of the next).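

In this assay, ethynyl in place of methyl on a saturated chain carbon bound to an aromatic nitrogen gives a 54-fold higher number from compound 3 to compound 4 (1.73 log units; beyond the scatter), so this site, with phenyl on the core, can raise the number by a large step. The earlier chain change ran the other way, with ethyl in place of hydrogen and 2,4-dimethylphenyl on the core giving a 9.9-fold lower number from compound 1 to compound 2 (1.00 log units; beyond the scatter). Chain extension therefore has no single direction across the compounds shown, although the two steps differ in the group on the core and are not a clean comparison, and nothing available here accounts for the rise in compound 4.

The compounds shown leave open whether the rise follows the triple bond itself or the longer chain, a question that a propyl or allyl group on the same aromatic nitrogen, with phenyl on the core, would address. Also open, on these data alone, is whether a butyl chain lowers the number with phenyl on the core as it does with 2,4-dimethylphenyl.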